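Aryl swap on the aminoketone series at the chain carbon

The source may hold more compounds than are shown below. What is called first, only, known or untested is meant among the compounds shown, and "the series" means these compounds.

Measured so far:
compound 1 `Cc1ccc(C(Nc2ccc(C)cc2Cl)C(=O)CCc2ccncc2)cc1` > 10000 nM
compound 2 `Cc1ccc(NC(C(=O)CCc2ccccn2)c2ccccc2Br)c(Cl)c1` > 10000 nM
compound 3 `Cc1cccc(C)c1C(Nc1ccc(Cl)cc1Cl)C(=O)CCc1ccncc1` 338 nM

Within the data shown here, in an assay on isolated protein for binding affinity to corticotropin-releasing factor receptor 1 (Homo sapiens) (on this read-out higher numbers stand for weaker inhibition and lower numbers for stronger inhibition), compound 3 gives 338 nM, the only numerical value among the three compounds examined. For compound 1 the result in this assay is a limit, > 10000 nM, not a number. For compound 2 the result in this assay is likewise a limit, > 10000 nM. Among the measured compounds shown here, both limits sit at the limit of > 10000 nM in this assay, at which 2 of the 3 values shown sit, so compound 3 stands alone as the one compound with a measurable value; no step between two measured compounds exists, and the gap from compound 3 to either limit cannot be sized.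

Compound 4 `O=C(CCc1ccncc1)C(Nc1ccc(Cl)cc1Cl)c1ccccc1C(F)(F)F` is not yet measured. It differs from compound 3 in one place: 2-(trifluoromethyl)phenyl in place of 2,6-dimethylphenyl on a saturated chain carbon bound to a carbonyl carbon and a nitrogen on an aromatic ring. Compound 2 carries a singly substituted aryl group on the same chain carbon, with a different aniline and a different pyridine link, and gives only a limit; compound 3 with the doubly substituted aryl gives a number. Whether the change to a single trifluoromethyl-bearing ring costs affinity cannot be read from these compounds alone.

The expectation for compound 4 is a loss beyond the scatter, a 4.4-fold higher number from compound 3 to compound 4 (0.65 log units; beyond the scatter), with an estimated value of 1500 nM within a range of 400 nM to 6000 nM.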

Compound 4, inhibition constant: 1000 nM
Compound 4: the middle estimate sits 1.5-fold (0.18 log units) above what was measured; low and high end bracket the measured number.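

In this assay, 2-(trifluoromethyl)phenyl in place of 2,6-dimethylphenyl on the saturated chain carbon gives a 3.0-fold higher number from compound 3 to compound 4 (0.47 log units; beyond the scatter). Among these compounds, this is the first step that can be read, and it shows that the position accepts a ring with a single substituent and still returns a number when the aniline and the pyridine link of compound 3 are kept, though at a modest cost in affinity. Compound 1 and compound 2 remain limits, not numbers, and each differs from compound 4 in more than one place, so steps to them cannot be read: the limit of > 10000 nM in this assay, at which 2 of the 4 values shown sit.

This one swap removes two methyl groups and brings in one trifluoromethyl group, so the compounds shown cannot say which of these changes carries the step; 2-methylphenyl on the same chain carbon would separate them. Also open, from the compounds shown here alone, is whether 2,6-dichlorophenyl or 2-methoxyphenyl would hold or improve the value, and whether any singly substituted ring returns a number with a different aniline or pyridine link.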